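A few compounds are considered here, and "the series" means these few. Any claim that something is new, unique, unknown or untested is made for them only; others in the source may bear on it.

Measured so far:
compound 1 `Cc1cc(=O)n(-c2ccccc2OC(F)(F)F)nc1C(=O)Nc1ccc(Oc2ncnc3ccsc23)c(F)c1`, 15700 nM in a functional assay on HepG2 cells (Homo sapiens) for cytotoxicity, read by MTT assay, with a stated time of 72 h; a higher number here means a weaker inhibitor, a lower number a stronger inhibitor
compound 2 `Cc1cc(=O)n(-c2cccc(F)c2)nc1C(=O)Nc1ccc(Oc2ncnc3ccsc23)c(F)c1`, 7810 nM in this assay

On these numbers compound 2 stands lowest, with compound 1 nearest at a 2.0-fold lower number from compound 1 to compound 2 (0.30 log units; within the scatter), so the two are not separated.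

Compound 3 `Cc1ccc(-n2nc(C(=O)Nc3ccc(Oc4ncnc5ccsc45)c(F)c3)c(C)cc2=O)cc1` is the next one. Its change from compound 2 is 4-methylphenyl in place of 3-fluorophenyl on an aromatic nitrogen. Among the compounds with values here, the only comparable step, the swap of the group on the same aromatic nitrogen from compound 1 to compound 2, was a 2.0-fold lower number from compound 1 to compound 2 (0.30 log units; within the scatter), too small to count. A step of similar size is therefore expected here, with no clear direction: the expected step is a 1.2-fold higher number from compound 2 to compound 3 (0.06 log units; within the scatter). Compound 3 is estimated at 9000 nM, between 3000 nM and 30000 nM.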

Compound 3, half-maximal inhibitory concentration: 17300 nM
Compound 3: the middle estimate sits 1.9-fold (0.28 log units) below what was measured; the range from low to high includes it.
By their numbers in this assay, from the lowest: compounds 2, 1 and 3 (each within the scatter of the next, the first and the last beyond it).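

Within the data shown here, putting 4-methylphenyl in place of 3-fluorophenyl on the aromatic nitrogen gives a 2.2-fold higher number from compound 2 to compound 3 (0.35 log units; beyond the scatter) in this assay and is the first step at this position to clear the scatter, though only modestly. Set against 2-(trifluoromethoxy)phenyl, 4-methylphenyl shows a 1.1-fold higher number from compound 1 to compound 3 (0.04 log units; within the scatter) so those two groups are not separated. This change swaps both the substituent and its place on the phenyl ring, so 3-methylphenyl and 4-fluorophenyl would be needed to tell these apart. From the compounds shown here alone, all three groups are substituted phenyl rings, so a pyridine, an amine or a longer alkyl chain on this nitrogen stays open. Nothing measured here explains the shift.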